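Ortho-Substituted Sulfonyl Aryl Amides as Potassium Channel Blockers

The compounds below may be only part of what the source reports. "The series", "measured", "known", "first", "only" and "open" are said of these compounds alone.

Of the compounds shown here, three sharing one amide core have been measured in a functional assay (Cavia porcellus) with sulfonylurea receptors; K-ATP channels (Homo sapiens) as the target; a higher number here means a weaker inhibitor, a lower number a stronger inhibitor. Compound 1 `CC(O)(C(=O)Nc1ccc(S(=O)(=O)c2ccccc2F)cc1)C(F)(F)F`, with a 2-fluorophenyl on the sulfonyl sulfur, gives 1300 nM. Compound 2 `COc1cccc(S(=O)(=O)c2ccc(NC(=O)C(C)(O)C(F)(F)F)cc2)c1` gives 16000 nM, and compound 3 `CC(O)(C(=O)Nc1ccc(S(=O)(=O)c2cccc(Cl)c2)cc1)C(F)(F)F` gives 10000 nM. Compound 3 thus stands second highest of the three numbers: its nearest neighbour is compound 2, with a 1.6-fold lower number from compound 2 to compound 3 (0.20 log units; within the scatter), a step within the scatter, while its furthest is compound 1, with a 7.7-fold higher number from compound 1 to compound 3 (0.89 log units; beyond the scatter). The related step of a 12-fold higher number from compound 1 to compound 2 (1.09 log units; beyond the scatter) points the same way.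

Compound 4 `Cc1ccccc1S(=O)(=O)c1ccc(NC(=O)C(C)(O)C(F)(F)F)cc1` differs from compound 3 by 2-methylphenyl in place of 3-chlorophenyl on a sulfonyl sulfur. Among the compounds with values here, no measured step exchanges a 3-substituted phenyl for a 2-substituted one other than the reverse of the step from compound 1 to compound 3, so that step and the value of compound 1 are the only guides. Compound 4 carries a 2-methylphenyl, and its closest measured analogue in this respect is compound 1, so the number for compound 4 in this assay is expected to fall below that of compound 3, by an estimated 4.0-fold lower number from compound 3 to compound 4 (0.60 log units; beyond the scatter). For compound 4 the estimate in this assay is 2500 nM, with a range from 800 nM to 8000 nM.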

Compound 4, half-maximal inhibitory concentration: 5100 nM
Compound 4: middle estimate off by 2.0-fold (0.31 log units), on the low side; the measured number falls inside the stated range.
By their numbers in this assay, from the lowest: compound 1; then compounds 4, 3 and 2 (each within the scatter of the next, the first and the last beyond it).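

In this assay, the 2-methylphenyl does not reproduce what the 2-fluorophenyl gives: methyl in place of fluoro on that aromatic carbon produces a 3.9-fold higher number from compound 1 to compound 4 (0.59 log units; beyond the scatter), so compound 1 keeps the lowest number of the four, and a substituent at the 2-position is not enough on its own in this small set. The 2-methylphenyl cannot be separated from the 3-chlorophenyl, at a 2.0-fold lower number from compound 3 to compound 4 (0.29 log units; within the scatter), yet it does separate from the 3-methoxyphenyl, at a 3.1-fold lower number from compound 2 to compound 4 (0.50 log units; beyond the scatter), which places compound 4 closer to the compounds with substituents at the 3-position than to compound 1, though not clear of all of them. The data offered here give no explanation for any of these differences.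

On these data alone, what a 3-fluorophenyl or a 3-methylphenyl would give on the same sulfonyl sulfur remains open, so the effect of the group and the effect of its place on the ring cannot yet be told apart. Also open, as far as these compounds go, is whether a 2-chlorophenyl would stay near compound 1 or near compound 4, and how an amine or a carboxylic acid on that ring would read in this assay.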